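A few compounds are considered here, and "the series" means these few. Any claim that something is new, unique, unknown or untested is made for them only; others in the source may bear on it.

Measured compounds in a functional assay on PC-3 cells (Homo sapiens) for inhibition, read by sulforhodamine B assay, with a stated time of 48 h; a lower number here means a stronger inhibitor of growth, a higher number a weaker inhibitor of growth:
compound 1 `Nc1cc(N)c2nc(-c3ccccc3)c(NCc3ccc(Cl)c(Cl)c3)nc2c1` gives 5130 nM
compound 2 `COc1ccc(CNc2nc3cc(N)cc(N)c3nc2-c2ccccc2)cc1OC` gives 27500 nM
compound 3 `CCOC(=O)[C@H](CCC(=O)O)NC(=O)c1ccc(Sc2nc3cc(N)cc(N)c3nc2-c2ccccc2)cc1` gives < 100000 nM, which is a limit of the assay and not a number

Among the numbers, compound 2 stands highest of the two available; its only numerical neighbour is compound 1, and the step of a 5.4-fold higher number from compound 1 to compound 2 (0.73 log units; beyond the scatter) lies beyond the scatter. The entry for compound 3 is only a limit of < 100000 nM in this assay, at which 1 of the 3 values shown sits, and gives nothing to rank against.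

Compound 4 `COc1cc(CNc2nc3cc(N)cc(N)c3nc2-c2ccccc2)cc(OC)c1OC` differs from compound 2 by methoxy in place of hydrogen on an aromatic carbon. Among the measured compounds shown here, no measured step adds or removes a methoxy group while the rest of the molecule stays fixed, so nothing bears directly on this change. For the measured compounds named here, the one step at this part of the molecule, a 5.4-fold higher number from compound 1 to compound 2 (0.73 log units; beyond the scatter), exchanged the whole aryl group and went towards a weaker number, which is a different change in kind. For compound 4 the expected outcome is therefore a number close to that of compound 2, with a step of a 1.3-fold higher number from compound 2 to compound 4 (0.10 log units; within the scatter) that is not expected to clear the scatter. Compound 4 is estimated at 35000 nM in this assay, within a range of 12000 nM to 100000 nM.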

Compound 4, concentration for total growth inhibition: < 50200 nM
Compound 4: no number, only a limit (the forecaster's own chance of this, stated with the estimate: 25%); the middle value is on the limit's open side.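

In this assay compound 4 gives < 50200 nM, which is a limit of the assay and not a number. The step between compound 2 and compound 4 therefore cannot be read. Still open, as far as these compounds go, is how methoxy in place of hydrogen on an aromatic carbon shifts the number in this assay.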